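The source may report more compounds than this note shows. Statements on the series, on what has been measured and on what is new or still open speak of the compounds shown alone.

Of the compounds shown here, three built on one shared core have been measured in an assay on isolated protein for activation of Nicotinamide phosphoribosyltransferase (Homo sapiens); on this read-out higher numbers stand for an effect only at larger amounts of compound and lower numbers for an effect already at smaller amounts. Compound 1 `CN(Cc1ccccc1)S(=O)(=O)c1ccc(NC(=O)NCc2ccncc2)cc1` gives 23 nM, compound 2 `NS(=O)(=O)c1ccc(NC(=O)NCc2ccncc2)cc1` gives 14300 nM, and compound 3 `O=C(NCc1ccncc1)Nc1ccc(S(=O)(=O)c2ccc(Cl)cc2)cc1` gives 126 nM, which places compound 3 second highest of the three, closer to compound 1 than to compound 2. The next compound, compound 4 `O=C(NCc1ccncc1)Nc1ccc(S(=O)(=O)N2CCc3ccccc3C2)cc1`, differs from compound 3 in a single place: 1,2,3,4-tetrahydroisoquinolin-2-yl in place of 4-chlorophenyl on a sulfonyl sulfur. Among the measured compounds shown here, two measured steps touch this position, a 5.5-fold higher number from compound 1 to compound 3 (0.74 log units; beyond the scatter) and a 110-fold lower number from compound 2 to compound 3 (2.05 log units; beyond the scatter), showing that the group on the sulfonyl sulfur can shift the outcome strongly in this assay. Because compound 1 gave 23 nM with benzyl(methyl)amino on the same sulfonyl sulfur, compound 4 is expected to give a lower number than compound 3, a 3.6-fold lower number from compound 3 to compound 4 (0.56 log units; beyond the scatter). The estimate for compound 4 is 35 nM, with a range from 10 nM to 120 nM.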

Compound 4, half-maximal effective concentration: 142 nM
For compound 4 the middle estimate is 4.1-fold (0.61 log units) below the measured one; measured number outside the range, above it.
By their numbers in this assay, from the lowest: compound 1; then compounds 3 and 4 (each within the scatter of the next); then compound 2.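

The step of a 1.1-fold higher number from compound 3 to compound 4 (0.05 log units; within the scatter) puts 1,2,3,4-tetrahydroisoquinolin-2-yl and 4-chlorophenyl on a level on the sulfonyl sulfur, so a nitrogen attached to that sulfur does not by itself bring the number down to that of compound 1. The step of a 6.2-fold higher number from compound 1 to compound 4 (0.79 log units; beyond the scatter) separates the ring-closed group from the open benzyl(methyl)amino, while the step of a 100-fold lower number from compound 2 to compound 4 (2.00 log units; beyond the scatter) shows that it still gives a far lower number than plain amino. Nothing measured here explains these differences. As far as these compounds go, it remains open how a longer chain, such as phenethyl(methyl)amino, or a smaller ring, such as pyrrolidin-1-yl, would compare on this sulfur.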